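Methyl to nitro on the benzyl arm and cytotoxicity

This account rests on a few compounds, and the source may have more. Where it says the series, first, only, none or still open, it means among the compounds named here.

Measured so far:
compound 1 `Cc1ccc(CN2c3ccccc3C(=O)N(Cc3ccccc3)S2(=O)=O)cc1` — 63000 nM
compound 2 `N#Cc1ccc(CN2c3ccccc3C(OCc3ccccc3)=NS2(=O)=O)cc1` — 62000 nM

In a functional assay on MRC5 cells (Homo sapiens) (a higher number here means that more compound is tolerated, a lower number that less compound is tolerated), compound 1 gives 63000 nM, the higher of the two numbers, but compound 2 sits so close to it that the two lie within the scatter. Compound 3 `O=C1c2ccccc2N(Cc2ccc([N+](=O)[O-])cc2)S(=O)(=O)N1Cc1ccccc1` differs from compound 1 in one place: nitro in place of methyl on an aromatic carbon. For the measured compounds named here, no step between measured compounds is available to gauge this exchange, so the expectation is that the step of a 1.1-fold lower number from compound 1 to compound 3 (0.02 log units; within the scatter) in this assay stays within the scatter, in no particular direction. Compound 3 is therefore estimated at 60000 nM, with a range from 25000 nM to 150000 nM.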

Compound 3, half-maximal cytotoxic concentration: > 59000 nM
Compound 3 ended at the assay's limit; the forecaster's own chance of this, stated with the estimate: 20%; the middle value lies beyond the limit too.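

In this assay compound 3 gives > 59000 nM, which is a limit of the assay, so no step can be read from compound 1 to compound 3. The compounds shown leave open whether going from 4-methylbenzyl to 4-nitrobenzyl changes the half-maximal cytotoxic concentration at all.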